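Removing the cyclopropylamino group from compound 2

The compounds below may be only part of what the source reports. "The series", "measured", "known", "first", "only" and "open" are said of these compounds alone.

Measured compounds:
compound 1 `CCNc1nccc(N2CC[C@H](NC(=O)Nc3ccc(Cl)c(C(F)(F)F)c3)C2)n1` — 8.9 nM
compound 2 `O=C(Nc1ccc(Cl)c(C(F)(F)F)c1)N[C@H]1CCN(c2ccnc(NC3CC3)n2)C1` — 20.3 nM

Both values come from an assay on a protein complex for displacement of a labelled ligand from CDK8/Cyclin C (Homo sapiens), read by TR-FRET, with a stated time of 1 h; on this read-out higher numbers stand for weaker inhibition and lower numbers for stronger inhibition. Compound 2 gives the higher of the two numbers; its nearest neighbour is compound 1, and the step of a 2.3-fold higher number from compound 1 to compound 2 (0.36 log units; beyond the scatter) shows the change of ethyl to cyclopropyl on the nitrogen attached to the aromatic ring.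

Compound 3 `O=C(Nc1ccc(Cl)c(C(F)(F)F)c1)N[C@H]1CCN(c2ccncn2)C1` takes this one bond further: hydrogen in place of cyclopropylamino on an aromatic carbon. Among the measured compounds shown here, no measured step removes this group outright, so the only guidance is that a change within the same group, in the step from compound 1 to compound 2, already moved the number beyond the scatter. Losing the group entirely is expected to cost more, with a step of a 15-fold higher number from compound 2 to compound 3 (1.17 log units; beyond the scatter). Compound 3 is therefore estimated at 300 nM, within a range from 50 nM to 3000 nM.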

Compound 3, half-maximal inhibitory concentration: 60.3 nM
Beside the measured number, compound 3's estimate is 5.0-fold (0.70 log units) above it; the range from low to high includes it.
By their numbers in this assay, from the lowest: compound 1; then compound 2; then compound 3.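

In this assay, replacing either amino group with hydrogen gives a 3.0-fold higher number from compound 2 to compound 3 (0.47 log units; beyond the scatter) and a 6.8-fold higher number from compound 1 to compound 3 (0.83 log units; beyond the scatter), so at this position between two ring nitrogen atoms both groups lower the number, with ethylamino giving the larger gain. Neither group is essential for inhibition, however: without any substituent there, compound 3 still gives 60.3 nM. No evidence here explains why these groups lower the number by these amounts.

From the compounds shown here alone, it remains open whether a plain amino group or a longer chain such as propylamino would give a lower number than ethylamino. It is also unknown whether the linking nitrogen itself matters, which a directly attached ethyl group or a methoxy group at the same position could help to test.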